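The source may hold more compounds than are shown below. What is called first, only, known or untested is meant among the compounds shown, and "the series" means these compounds.

The three compounds measured so far, all in a functional assay on DLD-1 cells (Homo sapiens) for cytotoxicity, with a stated time of 48 h (a higher number here means a weaker inhibitor, a lower number a stronger inhibitor), are:

compound 1, `CCCC(=O)Oc1ccc2oc(/C=C/[S+](C)[O-])cc(=O)c2c1`, which gives 8700 nM;
compound 2, `C[S+]([O-])/C=C/c1oc2ccccc2c(=O)c1Cc1ccccc1`, which gives 5100 nM;
compound 3, `COc1cccc2c(=O)cc(/C=C/[S+](C)[O-])oc12`, which gives 9000 nM.

Among these three numbers, compound 1 stands second highest. Its number lies very close to that of compound 3, and the gap to compound 2 is also within the usual scatter of repeated measurements, so no ordering of the three can be read from them. All three share the same core and the same methylsulfinylvinyl chain, and differ only in what is attached to the core and where.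

Compound 4, `CC(C)C(=O)Oc1ccc2oc(/C=C/[S+](C)[O-])cc(=O)c2c1`, has not yet been measured in this assay. It differs from compound 1 in a single place: isopropyl in place of propyl on a carbonyl carbon. The same three carbon atoms remain, simply joined in a branched rather than a straight arrangement, with no change in ring count, donors, acceptors or charge. Going by the values given here, no pair of measured compounds shows what such a change does here, so the expectation can rest only on how small the change is. The step expected, no change at the digits printed from compound 1 to compound 4 (within the scatter), amounts to nothing beyond the usual scatter. Compound 4 is therefore estimated to give about 8700 nM, with a likely range from 4300 nM to 17000 nM.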

Compound 4, half-maximal inhibitory concentration: 9100 nM
For compound 4 the middle estimate is 1.0-fold (0.02 log units) below the measured one; the range from low to high includes it.
By their numbers in this assay, from the lowest: compounds 2, 1, 3 and 4 (each within the scatter of the next).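

Swapping propyl for isopropyl on a carbonyl carbon gives a 1.0-fold higher number from compound 1 to compound 4 (0.02 log units; within the scatter) in this assay, and this is the first pair in the set that differs in one place only. At this position, then, joining the same carbon atoms in a branched rather than a straight arrangement produces no difference that can be told from ordinary repeat-to-repeat variation, although this single pair says nothing about other groups at the same place. Why the two chains read alike cannot be said, as no measurement at hand bears on that question.

From the compounds shown here alone, what remains open is whether a group of a different kind on that carbonyl carbon, such as a longer chain like octyl, a phenyl ring, an amine or a carboxylic acid, would move the number beyond the scatter. Also unsettled is how much the whole (propylcarbonyl)oxy group contributes, since the compounds shown offer no one-place comparison that replaces it with a hydrogen atom or a hydroxyl group.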